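Swapping an oxazole for a pyridine on a shared core

A few compounds are considered here, and "the series" means these few. Any claim that something is new, unique, unknown or untested is made for them only; others in the source may bear on it.

Compound 1 `Fc1ccc(-c2nn3c(NC4CCCC4)cccc3c2-c2ccnc(NC3CCCC3)c2)cc1`: > 40000 nM
Compound 2 `Cc1nc(-c2c(-c3ccc(F)cc3)nn3c(NC4CCCC4)cccc23)co1`: "not determined" (no result reported)

In an ADME assay on Vero cells (Chlorocebus sabaeus) for cytotoxicity (a higher number here means that more compound is tolerated, a lower number that less compound is tolerated), compound 1 is reported only as a limit of the assay, > 40000 nM. For compound 2 the outcome in this assay is "not determined" (no result reported), so compound 2 stands nowhere on the numbers shown; the only reported value is described by the limit of > 40000 nM in this assay, at which 1 of the 2 values shown sits. Compound 3 `Fc1ccc(-c2nn3c(NC4CCCC4)cccc3c2-c2ccncc2)cc1` differs from compound 2 in one place: pyridin-4-yl in place of 2-methyl-1,3-oxazol-4-yl on an aromatic carbon. Among the compounds with values here, since no number exists for compound 2, no step between compound 2 and compound 3 can be weighed, and nothing here points to a change beyond the scatter in this assay. Compound 3 shares its core with compound 1 and is expected to behave like compound 1 in this assay, most likely again reaching only a limit. For compound 3 the estimate in this assay is 50000 nM, within a range from 20000 nM to 150000 nM.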

Compound 3, half-maximal cytotoxic concentration: 20000 nM
Beside the measured number, compound 3's estimate is 2.5-fold (0.40 log units) above it; the measured number falls inside the stated range.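

In this assay, compound 3 gives 20000 nM, the only exact number among the compounds shown. Hydrogen in place of cyclopentylamino on an aromatic carbon gives an at least 2.0-fold lower number from compound 1 to compound 3 (0.30 log units; that floor lies within the scatter), so this change is not shown to make a real difference. The full size of the step stays unknown because the value for compound 1 is only a limit: the limit of > 40000 nM in this assay, at which 1 of the 3 values shown sits.

Compound 2 has no result, so the exchange of 2-methyl-1,3-oxazol-4-yl for pyridin-4-yl cannot be read in this assay. As far as these compounds go, it also remains open how a carboxylic acid or a primary amine in place of pyridin-4-yl would read on the shared core.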